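This account rests on a few compounds, and the source may have more. Where it says the series, first, only, none or still open, it means among the compounds named here.

In a functional assay on CWR22R cells (Homo sapiens) for antiproliferative activity, read by CCK-8 assay, with a stated time of 6 days (a higher number here means a weaker inhibitor, a lower number a stronger inhibitor), compound 1 `CCN(c1ccc(C#N)c(Cl)c1)c1cc(-c2ccncc2)ccc1C` gives 1030 nM. Compound 2 `CCN(c1ccc(C#N)c(Cl)c1)c1cc(-n2cccn2)ccc1C` reads > 30000 nM, which is a limit and not a number. As far as these compounds go, compound 3 `CCN(c1ccc(C#N)c(Cl)c1)c1cc(-n2ccnc2)ccc1C` reads > 30000 nM, also a limit, so its true position is unknown. Both compounds share that ceiling: the limit of > 30000 nM in this assay, at which 2 of the 3 values shown sit.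

Compound 4 `CCN(c1ccc(C#N)c(Cl)c1)c1cc(-c2cn[nH]c2)ccc1C` has the same atoms as compound 3, joined differently, with 1H-pyrazol-4-yl in place of 1H-imidazol-1-yl on an aromatic carbon.

Within the data shown here, two measured steps bear on this change: an at least 29-fold higher number from compound 1 to compound 2 (1.46 log units; beyond the scatter) and an at least 29-fold higher number from compound 1 to compound 3 (1.46 log units; beyond the scatter). Both are large and beyond the scatter, while a step that the two limits leave unreadable from compound 2 to compound 3 gives no usable size. Compound 4 joins its ring through a ring carbon, as compound 1 does, whereas compound 2 and compound 3 join theirs through a ring nitrogen. Among the measured compounds shown here, with only three compounds, this link is tentative, but it points towards the value of compound 1, 1030 nM.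

A large move to a lower number is therefore expected, as an at least 12-fold lower number from compound 3 to compound 4 (1.07 log units; beyond the scatter). For compound 4 the estimate is 2500 nM, with an expected range of 400 nM to 15000 nM.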

Compound 4, half-maximal inhibitory concentration: > 30000 nM
Compound 4 ended at the assay's limit; the forecaster's own chance of this, stated with the estimate: 15%; middle value at least 12-fold (1.07 log units) away from the limit.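

In this assay, joining a five-membered ring through a ring carbon does not by itself keep the reading given by pyridin-4-yl, with an at least 29-fold higher number from compound 1 to compound 4 (1.46 log units; beyond the scatter). Compound 4 therefore goes against the tentative link between the joining atom and the read-out, and among the compounds shown only compound 1, with its pyridin-4-yl group, gives a reading short of the ceiling. The steps among compound 2, compound 3 and compound 4 cannot be read, so these three five-membered rings cannot be ordered: the limit of > 30000 nM in this assay, at which 3 of the 4 values shown sit.

Compound 1 is the only six-membered ring shown at this position, so it remains open whether ring size or the ring nitrogen matters more. A phenyl or pyridin-3-yl group here would help separate the two.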